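This account rests on a few compounds, and the source may have more. Where it says the series, first, only, none or still open, it means among the compounds named here.

Measured so far: compound 1 `CC1=CC[C@H]2[C@H](CC[C@]2(C)O)C(C)(C)[C@@H]1CC[C@H]1[C@]2(C)CC[C@H](OCc3ccccc3)C(C)(C)O[C@H]2CC[C@@]1(C)O`, 29100 nM in a functional assay on MDA-MB-231 cells (Homo sapiens) for antiproliferative activity, read by MTT assay, with a stated time of 72 h; on this read-out higher numbers stand for weaker inhibition and lower numbers for stronger inhibition; compound 2 `CC1=C(CC[C@H]2[C@]3(C)CC[C@H](O)C(C)(C)O[C@H]3CC[C@@]2(C)O)[C@](C)(C/C=C/C(C)(C)OO)[C@H](O)CC1`, > 50000 nM in this assay.

For compound 2 this assay reports only a limit, not a number: the limit of > 50000 nM in this assay, at which 1 of the 2 values shown sits. Compound 2 therefore stands at the limit end of the two values shown. Compound 3 `CC(C)=CCC[C@@]1(C)C(CC[C@H]2[C@]3(C)CC[C@H](O)C(C)(C)O[C@H]3CC[C@@]2(C)O)=C(C)CC[C@H]1O` differs from compound 2 in one place: a group of 5 heavy atoms (5 carbon; no ring) in place of a group of 7 heavy atoms (5 carbon, 2 oxygen; no ring), on a saturated chain carbon bound to a saturated ring carbon. Going by the values given here, no step between measured compounds is available for this change, so the expected step to compound 3 in this assay is an at least 1.2-fold lower number from compound 2 to compound 3 (0.09 log units; that floor lies within the scatter), small and not clearly beyond the scatter. Compound 3 is expected to give about 40000 nM in this assay, within 15000 nM to 100000 nM, with a real chance that only a limit is reported again.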

Compound 3, half-maximal inhibitory concentration: > 50000 nM
Compound 3 gave a limit, no number (the forecaster's own chance of this, stated with the estimate: 45%); middle value at least 1.2-fold (0.09 log units) from the limit.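

In this assay compound 2 and compound 3 each give only a limit, so no step can be read between them: the limit of > 50000 nM in this assay, at which 2 of the 3 values shown sit.

Going by these compounds, whether the 3-methylbut-2-en-1-yl group of compound 3 changes the read-out relative to the group in compound 2 remains open.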